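A few compounds are considered here, and "the series" means these few. Any claim that something is new, unique, unknown or untested is made for them only; others in the source may bear on it.

Measured in a functional assay on THP-1 cells (Homo sapiens) for inhibition, read by ELISA, with stated times of 1 h and 18 h; on this read-out lower numbers stand for stronger inhibition and higher numbers for weaker inhibition:
- compound 1 `NC(=O)[C@@H]1[C@H](Nc2nc(Nc3cccc(C(=O)N4CCCC4)c3)ncc2-c2cccnc2)[C@H]2C=C[C@@H]1C2`: 320 nM
- compound 2 `NC(=O)[C@@H]1[C@H](Nc2nc(Nc3cccc(C(=O)N4CCCC4)c3)ncc2-c2ccccc2)[C@H]2C=C[C@@H]1C2`: 220 nM
- compound 3 `NC(=O)[C@@H]1[C@H](Nc2nc(Nc3cccc(C(=O)N4CCCC4)c3)ncc2-c2ccncc2)[C@H]2C=C[C@@H]1C2`: 320 nM

Compound 3 stands level with compound 1 at the digits given, and its gap to compound 2 lies within the scatter, as a 1.5-fold higher number from compound 2 to compound 3 (0.16 log units; within the scatter) shows. The next compound, compound 4 `NC(=O)[C@@H]1[C@H](Nc2nc(Nc3cccc(C(=O)N4CCCC4)c3)ncc2-c2ccccc2F)[C@H]2C=C[C@@H]1C2`, keeps the shared core and differs at a single place: 2-fluorophenyl in place of pyridin-4-yl on an aromatic carbon. In words, this is 2-fluorophenyl in place of pyridin-4-yl on an aromatic carbon.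

All three measured steps concern this same place. Besides the step already given, they are a 1.5-fold lower number from compound 1 to compound 2 (0.16 log units; within the scatter) and no change at the digits printed from compound 1 to compound 3 (within the scatter). Each of them stays within the scatter, so exchanging pyridin-3-yl, pyridin-4-yl and phenyl has not yet moved the read-out measurably. Going by the values given here, no compound carrying a fluorine on this ring has been measured, and the data therefore cannot show what that atom adds on its own. On this evidence, no step beyond the scatter is expected in this assay, and no firm direction can be given. The estimated step is a 1.3-fold lower number from compound 3 to compound 4 (0.11 log units; within the scatter). For compound 4 the expected value is 250 nM, with an estimated range of 110 nM to 550 nM.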

Compound 4, half-maximal inhibitory concentration: 130 nM
Estimate against measurement, compound 4: 1.9-fold (0.28 log units) above; measured number inside the range.
By their numbers in this assay, from the lowest: compounds 4, 2, 1 and 3 (each within the scatter of the next, the first and the last beyond it).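

In this assay this position now shows its first steps beyond the scatter: 2-fluorophenyl in place of pyridin-4-yl gives a 2.5-fold lower number from compound 3 to compound 4 (0.39 log units; beyond the scatter) and 2-fluorophenyl in place of pyridin-3-yl gives a 2.5-fold lower number from compound 1 to compound 4 (0.39 log units; beyond the scatter), both of modest size. Going by these compounds alone, the one comparison that isolates the fluorine, fluoro in place of hydrogen on the phenyl ring, gives a 1.7-fold lower number from compound 2 to compound 4 (0.23 log units; within the scatter) and so stays inside the scatter, which means that both steps beyond it remove the ring nitrogen and add the fluoro at the same time, and the fluoro alone has no measurable effect to its name. Nothing shown here gives a reason for these steps.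

From the compounds shown here alone, whether a chloro, methyl or methoxy group in place of the fluoro would give a similar reading remains open. So does the effect of a fluoro carried on a pyridin-3-yl or pyridin-4-yl ring, a comparison that would separate the contribution of the ring nitrogen from that of the fluoro at this position.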